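Swapping trifluoromethyl for methyl in compound 2

The source may hold more compounds than are shown below. What is called first, only, known or untested is meant among the compounds shown, and "the series" means these compounds.

Going by the values given here, in a functional assay on MCF7 cells (Homo sapiens) for antiproliferative activity, read by MTT assay, with a stated time of 72 h (on this read-out lower numbers stand for stronger inhibition and higher numbers for weaker inhibition), compound 2 (`COc1cc(-n2cnc3ccc(-c4ccc(C(F)(F)F)cc4)cc32)cc(OC)c1OC`) gives 760 nM, the higher of the two exact numbers so far. Compound 1 (`COc1cc(-n2cnc3ccc(-c4ccc(C)cc4F)cc32)cc(OC)c1OC`) gives 56 nM. For compound 3 (`COc1cc(-c2ccc3ncn(-c4cc(OC)c(OC)c(OC)c4)c3c2)cc(OC)c1OC`) the result is a limit, > 10000 nM.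

Compound 4 (`COc1cc(-n2cnc3ccc(-c4ccc(C)cc4)cc32)cc(OC)c1OC`) differs from compound 2 in one place, with methyl in place of trifluoromethyl on an aromatic carbon. Among the compounds with values here, one measured step bears on this: a 14-fold higher number from compound 1 to compound 2 (1.13 log units; beyond the scatter). This large step, beyond the scatter, replaces 2-fluoro-4-methylphenyl with 4-(trifluoromethyl)phenyl. Compound 4 carries 4-methylphenyl, so it shares the methyl of compound 1 but lacks its fluorine. That step therefore mixes two changes, and only part of it may carry over. The expected change in this assay is a 6.3-fold lower number from compound 2 to compound 4 (0.80 log units; beyond the scatter), towards a lower number and beyond the scatter. For compound 4 the estimated value is 120 nM, with an expected range from 40 nM to 400 nM.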

Compound 4, half-maximal inhibitory concentration: 110 nM
Compound 4: the middle estimate sits 1.1-fold (0.04 log units) above what was measured, within the range that was stated.
By their numbers in this assay, from the lowest: compounds 1 and 4 (each within the scatter of the next); then compound 2. At a limit, above all of these: compound 3.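

Compounds 2 and 4 both lack the ring fluorine of compound 1, so this pair tests the trifluoromethyl-to-methyl swap on its own. In this assay the swap gives a 6.9-fold lower number from compound 2 to compound 4 (0.84 log units; beyond the scatter), a clear change at this aromatic carbon that the earlier mixed step could not assign to one group. Removing the fluorine, by contrast, gives a 2.0-fold higher number from compound 1 to compound 4 (0.29 log units; within the scatter), so hydrogen and fluoro cannot be told apart in this pair, and nothing measured here explains why either change has the size it does.

The compounds shown leave open how an ethyl group, a methoxy group or an amine would read at the carbon that holds methyl in compound 4. On these data alone, it also remains open whether adding fluoro to compound 2, as compound 1 carries it, would stay within the scatter too.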